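A few compounds are considered here, and "the series" means these few. Any claim that something is new, unique, unknown or untested is made for them only; others in the source may bear on it.

Compound 1 `CC1(C)OC(=O)C2(C(=O)O1)[C@@H](c1ccc(O)cc1)CC(=O)C[C@H]2c1ccc(O)cc1` gives 87000 nM
Compound 2 `Oc1ccc(-c2ccc(-c3cc(O)cc(O)c3)cc2)cc1` gives 7000 nM

In a functional assay on HL-60 cells (Homo sapiens) for antiproliferative activity, read by trypan blue exclusion, with a stated time of 48 h (a lower number here means a stronger inhibitor, a higher number a weaker inhibitor), compound 2 holds the lower of the two numbers, with a gap beyond the scatter from compound 1. Compound 3 `Oc1ccc(-c2cc(O)cc(O)c2)cc1` differs from compound 2 by hydroxy in place of 4-hydroxyphenyl on an aromatic carbon with hydroxy in place of 4-hydroxyphenyl on an aromatic carbon. Within the data shown here, no measured step covers this change, so the expectation in this assay is only a judgement: a higher number, by a step beyond the scatter. The expected step is a 3.6-fold higher number from compound 2 to compound 3 (0.55 log units; beyond the scatter) in size. For compound 3 the estimated value is 25000 nM with 8000 nM to 80000 nM as the expected range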

Compound 3, half-maximal inhibitory concentration: > 80000 nM
Compound 3 gave a limit, no number; the forecaster's own chance of this, stated with the estimate: 10%; at least 3.2-fold (0.50 log units) between middle value and limit.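

With hydroxy in place of 4-hydroxyphenyl on this aromatic carbon, this assay shows an at least 11-fold higher number from compound 2 to compound 3 (1.05 log units; beyond the scatter). At this position, activity therefore goes with the 4-hydroxyphenyl and is not kept by hydroxy, although both groups count the same hydrogen-bond donors and acceptors. Compound 3 has only a limit, not a number, so the step gives a minimum size: the limit of > 80000 nM in this assay, at which 1 of the 3 values shown sits.

On these data alone, whether an amine, a carboxylic acid or a longer chain on this carbon would keep the activity of compound 2 stays open.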